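This account rests on a few compounds, and the source may have more. Where it says the series, first, only, none or still open, it means among the compounds named here.

Working notes on the series. In a functional assay on LNCaP cells (Homo sapiens) for antiproliferative activity, read by propidium iodide staining, with a stated time of 96 h (a higher number here means a weaker inhibitor, a lower number a stronger inhibitor), compound 1 (`CC(O)(CSc1cccc(S(F)(F)(F)(F)F)c1)C(=O)Nc1ccc(C#N)c(C(F)(F)F)c1`) gives 14500 nM, compound 2 (`CC(O)(CSc1cccc(S(F)(F)(F)(F)F)c1)C(=O)Nc1ccc([N+](=O)[O-])c(C(F)(F)F)c1`) gives 8600 nM and compound 3 (`CC(O)(CSc1ccc(S(F)(F)(F)(F)F)cc1)C(=O)Nc1ccc(C#N)cc1C(F)(F)F`) gives 15100 nM. Compound 3 lies within the scatter of both other compounds, so these numbers do not separate the three.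

The next step leads to compound 4 (`CC(O)(CSc1ccc(S(F)(F)(F)(F)F)cc1)C(=O)Nc1ccc([N+](=O)[O-])cc1C(F)(F)F`), which carries nitro in place of cyano on an aromatic carbon, meta to a trifluoromethyl group and para to a large group: nitro in place of cyano on an aromatic carbon.

Going by the values given here, only one measured step bears on this exchange, and it sits on the core of compound 1: a 1.7-fold lower number from compound 1 to compound 2 (0.23 log units; within the scatter). Among the compounds with values here, that single step stays within the scatter, and no measured pair tests the exchange on the core of compound 3. A change beyond the scatter in this assay is therefore not expected, though a small shift in the same direction is possible.

The estimated step is a 1.5-fold lower number from compound 3 to compound 4 (0.18 log units; within the scatter). The expected value for compound 4 is 10000 nM, with an estimated range of 5000 nM to 20000 nM.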

Compound 4, half-maximal inhibitory concentration: 10300 nM
The estimate for compound 4 lay 1.0-fold (0.01 log units) below the measured number; low and high end bracket the measured number.
By their numbers in this assay, from the lowest: compounds 2, 4, 1 and 3 (each within the scatter of the next).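

In this assay the exchange of cyano for nitro now has a second reading, on the core of compound 3, where the group sits meta to a trifluoromethyl group: a 1.5-fold lower number from compound 3 to compound 4 (0.17 log units; within the scatter). The earlier single step therefore no longer stands alone, and the two readings lie within the scatter of each other: the same change on two cores in this assay, a 1.7-fold lower number (0.23 log units; within the scatter) from compound 1 to compound 2 and a 1.5-fold lower number (0.17 log units; within the scatter) from compound 3 to compound 4, 1.2-fold (0.06 log units) apart, within the scatter of two such steps. On these two cores, nitro and cyano on this aromatic carbon are not separated by this assay.

Going by these compounds, whether another group on this carbon, such as an amine or a carboxylic acid, would give a step beyond the scatter remains open. On these data alone, compound 1 and compound 3 differ in more than one place, so the share of each place in any difference between the cores also remains open.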